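The compounds below may be only part of what the source reports. "The series", "measured", "known", "first", "only" and "open" are said of these compounds alone.

In a functional assay on the whole organism with Oryctolagus cuniculus as the target (on this read-out lower numbers stand for stronger inhibition and higher numbers for weaker inhibition), compound 1 `CO/C(O)=C1\C(C)=Nc2ccccc2SC1c1cccc([N+](=O)[O-])c1` gives 1200 nM while compound 2 `CO/C(O)=C1\C(C)=Nc2ccccc2SC1c1ccccc1[N+](=O)[O-]` gives 300 nM and so holds the lower number of the two, which means the stronger inhibition, with a gap beyond the usual scatter of repeat measurements. Compound 3 `CO/C(O)=C1\C(C)=Nc2ccccc2SC1c1ccccc1C(F)(F)F` keeps the shared core of compound 2 and carries trifluoromethyl in place of nitro on an aromatic carbon, ortho to a large group. The counted change is trifluoromethyl in place of nitro on an aromatic carbon and it is the only difference between the two structures. Among the measured compounds shown here, no measured pair shows this swap, so the expectation rests on judgment alone. No step beyond the usual scatter is expected in this assay with only a slight lean toward a higher number. The estimated change is a 1.3-fold higher number from compound 2 to compound 3 (0.12 log units; within the scatter) and it would stay small. For compound 3 the expected value is 400 nM within an estimated range from 120 nM to 1300 nM for this measurement.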

Compound 3, half-maximal inhibitory concentration: 12000 nM
Compound 3: the middle estimate sits 30-fold (1.48 log units) below what was measured; the whole stated range lies below it.
By their numbers in this assay, from the lowest: compound 2; then compound 1; then compound 3.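

In this assay, replacing nitro with trifluoromethyl on this aromatic carbon, ortho to a large group, is far from a neutral exchange: it gives a 40-fold higher number from compound 2 to compound 3 (1.60 log units; beyond the scatter), a large step beyond the scatter. Among the compounds shown here, the earlier compounds held no exchange of one group for another at this place, so this is the first sign that the group here strongly shapes the read-out, with nitro giving much stronger inhibition than trifluoromethyl in this pair. Nothing measured on these compounds explains the loss of inhibition. Still open, going by these compounds, is whether any other group, such as a nitrile, an amine, a carboxylic acid or a methyl, can match nitro on this carbon. Also open, on these data alone, is whether the same exchange would produce a step of similar size on another aromatic carbon of this ring.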